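The compounds below may be only part of what the source reports. "The series", "measured", "known", "first", "only" and "open" are said of these compounds alone.

Compound 1 `CCC(CC)N(CCN(C)C(=O)CCC(=O)O)Cc1cccc(C(=O)Nc2sc3c(c2C(=O)c2cnn(-c4ccc(Cl)c(C(F)(F)F)c4)c2)CCC(C)(C)C3)c1` gives 38 nM in an assay on isolated protein for inhibition of sodium-dependent phosphate transport protein 2B (Homo sapiens); on this read-out lower numbers stand for stronger inhibition and higher numbers for weaker inhibition. Compound 2 `CCC(CC)N(CCN(C)C(=O)CCC(=O)O)Cc1cccc(C(=O)Nc2sc3c(c2C(=O)c2cnn(-c4cccc(C(F)(F)F)c4)c2)CCC(C)(C)C3)c1` gives 46 nM in this assay.

Compound 2 stands highest of the two numbers, its nearest neighbour being compound 1, within the scatter. Compound 3 `CCC(CC)N(CCN(C)C(=O)CCC(=O)O)Cc1cccc(C(=O)Nc2sc3c(c2C(=O)c2cnn(Cc4ccccc4)c2)CCC(C)(C)C3)c1` differs from compound 2 by benzyl in place of 3-(trifluoromethyl)phenyl on an aromatic nitrogen. Among the compounds with values here, the only measured step on the same aryl group, a 1.2-fold higher number from compound 1 to compound 2 (0.08 log units; within the scatter), was within the scatter, but that step altered one substituent, whereas here the whole aryl group gives way to a benzyl, which no measured step covers. A modest weakening is therefore expected, a 3.3-fold higher number from compound 2 to compound 3 (0.51 log units; beyond the scatter). Compound 3 is estimated at 150 nM, within 40 nM to 600 nM.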

Compound 3, half-maximal inhibitory concentration: 179 nM
Compound 3: middle estimate off by 1.2-fold (0.08 log units), on the low side; measured number inside the range.
By their numbers in this assay, from the lowest: compounds 1 and 2 (each within the scatter of the next); then compound 3.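

On the aromatic nitrogen, the aryl group can be changed in a way that moves the number beyond the scatter, which the loss of chloro alone did not do. In this assay, benzyl in place of 3-(trifluoromethyl)phenyl gives a 3.9-fold higher number from compound 2 to compound 3 (0.59 log units; beyond the scatter), and benzyl in place of 4-chloro-3-(trifluoromethyl)phenyl gives a 4.7-fold higher number from compound 1 to compound 3 (0.67 log units; beyond the scatter). Nothing available explains this weakening.

The compounds shown do not separate the loss of trifluoromethyl from the change from phenyl to benzyl. A plain phenyl or a 3-(trifluoromethyl)benzyl group on this nitrogen would separate them.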